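Fluorine Shifted Around the Benzyloxy Ring

A few compounds are considered here, and "the series" means these few. Any claim that something is new, unique, unknown or untested is made for them only; others in the source may bear on it.

Compound 1 `COc1cc(OC)c(-c2coc3cc(OCc4ccccc4)ccc3c2=O)cc1OC`: 1640 nM
Compound 2 `COc1cc(OC)c(-c2coc3cc(OCc4ccc(F)cc4)ccc3c2=O)cc1OC`: 1720 nM

In a functional assay on A-375 cells (Homo sapiens) for antiproliferative activity, read by MTT assay, with a stated time of 24 h (on this read-out higher numbers stand for weaker inhibition and lower numbers for stronger inhibition), compound 1 gives 1640 nM, the lowest of the two numbers seen so far, and compound 2 gives 1720 nM. Among the measured compounds shown here, the only measured step, a 1.0-fold higher number from compound 1 to compound 2 (0.02 log units; within the scatter), stayed flat. Compound 3 `COc1cc(OC)c(-c2coc3cc(OCc4cccc(F)c4)ccc3c2=O)cc1OC` differs from compound 1 by fluoro in place of hydrogen on an aromatic carbon. Since the related step of a 1.0-fold higher number from compound 1 to compound 2 (0.02 log units; within the scatter) showed nothing beyond the scatter, the step expected in this assay is a 1.0-fold higher number from compound 1 to compound 3 (0.02 log units; within the scatter), with no movement beyond the scatter. Compound 3 is therefore estimated at 1700 nM, with a range from 900 nM to 3300 nM.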

Compound 3, half-maximal inhibitory concentration: 1300 nM
Compound 3: the middle estimate sits 1.3-fold (0.12 log units) above what was measured; the range from low to high includes it.
By their numbers in this assay, from the lowest: compounds 3, 1 and 2 (each within the scatter of the next).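

In this assay the 3-fluorobenzyl compound also stays within the scatter, with a 1.3-fold lower number from compound 1 to compound 3 (0.10 log units; within the scatter) and with a 1.3-fold lower number from compound 2 to compound 3 (0.12 log units; within the scatter) as well. Fluoro in place of hydrogen on this ring has now been seen at two places without a change beyond the scatter, and shifting it from the 4-fluorophenyl to the 3-fluorophenyl group gives none either. No evidence at hand bears on this result. The compounds shown leave open whether a group other than fluoro on this ring, such as chloro, methoxy or an amine, would move the number beyond the scatter.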